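Silyl ether on the trimethoxyphenyl ring: two hydroxyl isomers

The source may report more compounds than this note shows. Statements on the series, on what has been measured and on what is new or still open speak of the compounds shown alone.

Compound 1 `COc1cc(-c2cc(=O)c3cc(O)ccc3o2)cc(OC)c1OC` and compound 2 `COc1cc(-c2cc(=O)c3ccc(O)cc3o2)cc(OC)c1OC` share the same atoms joined differently; the difference between the two cores is not broken down here. In a functional assay on SK-MEL cells (Homo sapiens) for cytotoxicity, read by MTT assay, with a stated time of 6 days (a lower number here means that less compound is needed, a higher number that more compound is needed for the effect), compound 1 gives 5.87 ug/mL. For compound 2 only a limit is reported, > 25 ug/mL, as noted in the limit of > 25 ug/mL in this assay, at which 1 of the 3 values shown sits. Compound 3 `COc1cc(-c2cc(=O)c3cc(O)ccc3o2)cc(OC)c1O[Si](C)(C)C(C)(C)C` carries a group of 7 heavy atoms (6 carbon, 1 silicon; no ring) in place of one carbon atom, on an oxygen on an aromatic ring, and in this assay compound 3 gives 2.95 ug/mL, a step of a 2.0-fold lower number from compound 1 to compound 3 (0.30 log units; within the scatter). Compound 4 `COc1cc(-c2cc(=O)c3ccc(O)cc3o2)cc(OC)c1O[Si](C)(C)C(C)(C)C` carries the same kind of change on the core of compound 2, (a group of 7 heavy atoms (6 carbon, 1 silicon; no ring) in place of one carbon atom, on an oxygen on an aromatic ring). Since the measured step from compound 1 to compound 3 stays within the scatter, the step from compound 2 to compound 4 is expected to be similar, a step that the limit leaves unreadable from compound 2 to compound 4, although it starts from a limit. Compound 4 is therefore estimated at 30 ug/mL, within 12 ug/mL to 80 ug/mL.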

Compound 4, concentration for half-maximal effect: > 25 ug/mL
Compound 4: no number, only a limit (the forecaster's own chance of this, stated with the estimate: 60%); the middle value is on the limit's open side.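

Compound 2 and compound 4 are both reported only as limits, so no step can be read between them: the limit of > 25 ug/mL in this assay, at which 2 of the 4 values shown sit.

Left open is whether replacing methyl on the oxygen on an aromatic ring changes the number at all on the core of compound 2.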